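Extending Phenyl to 2-Phenylethenyl in a Cytotoxicity Series

The source may report more compounds than this note shows. Statements on the series, on what has been measured and on what is new or still open speak of the compounds shown alone.

Three compounds have been measured in a functional assay on HepG2 cells (Homo sapiens) for cytotoxicity, read by MTT assay, with a stated time of 48 h; a higher number here means a weaker inhibitor, a lower number a stronger inhibitor:

Compound 1 `O=C(CSc1nnc(-c2ccncc2)o1)N/N=C/c1ccccc1` gives 17300 nM.
Compound 2 `O=C(CSc1nnc(-c2ccncc2)o1)N/N=C/c1ccc([N+](=O)[O-])cc1` gives 17900 nM.
Compound 3 `COc1ccc(/C=N/NC(=O)CSc2nnc(-c3ccncc3)o2)cc1` gives 15800 nM.

Compound 1 stands second highest of the three numbers. Its nearest neighbour is compound 2, with a 1.0-fold higher number from compound 1 to compound 2 (0.01 log units; within the scatter), and its furthest is compound 3, with a 1.1-fold lower number from compound 1 to compound 3 (0.04 log units; within the scatter). The remaining pair shows a 1.1-fold lower number from compound 2 to compound 3 (0.05 log units; within the scatter). All three steps lie within the scatter, so the three compounds cannot be told apart on these numbers.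

Compound 4 `O=C(CSc1nnc(-c2ccncc2)o1)N/N=C/C=C/c1ccccc1` is not yet measured. It differs from compound 1 as follows: 2-phenylethenyl in place of phenyl on a carbon with a double bond to nitrogen. None of the three measured steps bears directly on this change: each of them swaps a substituent on the aromatic ring, whereas here the group attached to the carbon double-bonded to nitrogen is itself exchanged. What the measured steps do show is that, in this small set, changing the aromatic part of that group left the number within the scatter every time.

On that basis, the expected step is a 1.0-fold lower number from compound 1 to compound 4 (0.01 log units; within the scatter), that is, no change beyond the scatter, though with less confidence than for the ring substituents. The estimate for compound 4 in this assay is 17000 nM, in a range from 7000 nM to 40000 nM.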

Compound 4, half-maximal inhibitory concentration: 7420 nM
Estimate against measurement, compound 4: 2.3-fold (0.36 log units) above, within the range that was stated.
By their numbers in this assay, from the lowest: compound 4; then compounds 3, 1 and 2 (each within the scatter of the next).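

At this position, on a carbon with a double bond to nitrogen, changing a substituent on the aromatic ring left the number in this assay within the scatter, whereas replacing phenyl with 2-phenylethenyl moves it beyond the scatter, though only modestly (a 2.3-fold lower number from compound 1 to compound 4 (0.37 log units; beyond the scatter)). The same holds against both ring-substituted compounds (a 2.1-fold lower number from compound 3 to compound 4 (0.33 log units; beyond the scatter); a 2.4-fold lower number from compound 2 to compound 4 (0.38 log units; beyond the scatter)), so compound 4 has the lowest number of the four and is the only one that can be separated from the rest. The aromatic ring stays in place and the change adds a double bond outside it, but nothing shown here explains why the number falls.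

On these data alone, what remains open is whether the double bond itself matters or only the longer reach of the group, which a saturated 2-phenylethyl group at the same place would help to separate. As far as these compounds go, it is also open whether methoxy or nitro on the ring of the 2-phenylethenyl group would leave the number unchanged, as they do on the phenyl of compound 1.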